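Trifluoromethyl in Place of Difluoromethyl at the Toxicity Limit

The source may hold more compounds than are shown below. What is called first, only, known or untested is meant among the compounds shown, and "the series" means these compounds.

Measured compounds in an ADME assay on MDCK cells (Canis lupus familiaris) for cytotoxicity, read by MTT assay, with a stated time of 48 h; on this read-out higher numbers stand for lower toxicity in this test and lower numbers for higher toxicity in this test:
compound 1 `NC(=O)c1c(NC(=O)c2cnn3c(C(F)F)cc(-c4ccccc4)nc23)sc2c1CCC2`: > 250000 nM
compound 2 `NC(=O)c1c(NC(=O)c2cnn3c(C(F)(F)F)cc(-c4ccccc4)nc23)sc2c1CCC2`: > 250000 nM
compound 3 `NC(=O)c1c(NC(=O)c2cnn3c(C(F)F)cc(-c4ccccc4)nc23)sc2c1CCCC2`: > 250000 nM

In this assay compound 1 gives a value that is a limit of the assay, not a number. Compound 2 likewise gives only a limit. Compound 3 stands at a limit as well, so its place on the numbers shown is defined only by that limit; all three shown values sit there (the limit of > 250000 nM in this assay, at which 3 of the 3 values shown sit). For the measured compounds named here, the one measured step, a step that the two limits leave unreadable from compound 1 to compound 2, is unreadable, both of its ends being limits.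

Compound 4 `NC(=O)c1c(NC(=O)c2cnn3c(C(F)(F)F)cc(-c4ccccc4)nc23)sc2c1CCCC2` differs from compound 3 by fluoro in place of hydrogen on a saturated chain carbon bound to an aromatic carbon and two fluorine atoms. Going by the values given here, the only step that bears on this change, a step that the two limits leave unreadable from compound 1 to compound 2, gives no size, so no change beyond the scatter of this assay is expected from compound 3 to compound 4, and the expected step is a step that the limit leaves unreadable from compound 3 to compound 4. Compound 4 is estimated to give 300000 nM in this assay, in the range from 250000 nM to 1000000 nM, most likely again reported only as a limit.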

Compound 4, half-maximal cytotoxic concentration: > 250000 nM
Compound 4 gave a limit, no number (the forecaster's own chance of this, stated with the estimate: 90%); the middle value lies beyond the limit too.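

In this assay compound 3 and compound 4 both give only a limit, not a number, so no step can be read between them: the limit of > 250000 nM in this assay, at which 4 of the 4 values shown sit.

The compounds shown leave open how far any of them lies beyond that limit, and whether difluoromethyl and trifluoromethyl differ there at all.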